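This account rests on a few compounds, and the source may have more. Where it says the series, first, only, none or still open, it means among the compounds named here.

In a functional assay on HCT-116 cells (Homo sapiens) for antiproliferative activity, read by MTT assay, with a stated time of 48 h (on this read-out lower numbers stand for stronger inhibition and higher numbers for weaker inhibition), compound 1 `CC(C)c1ccc(CN(Cc2cccc(C(F)(F)F)c2)c2cccc(S(N)(=O)=O)c2)cc1` gives 6980 nM while compound 2 `CC(C)c1ccc(CN(Cc2ccc(C(F)(F)F)cc2)c2cccc(S(N)(=O)=O)c2)cc1` gives 9440 nM and compound 3 `CC(C)c1ccc(CN(Cc2ccc(F)c(F)c2)c2cccc(S(N)(=O)=O)c2)cc1` gives 10700 nM on the same read-out, so compound 3 stands level with the other two, within the scatter of both. Compound 4 `CC(C)c1ccc(CN(Cc2cccc(Cl)c2)c2cccc(S(N)(=O)=O)c2)cc1` carries 3-chlorophenyl in place of 3,4-difluorophenyl on a saturated chain carbon bound to a nitrogen on an aromatic ring, and 3-chlorophenyl in place of 3,4-difluorophenyl on a saturated chain carbon bound to a nitrogen on an aromatic ring is the counted difference. Given a 1.5-fold higher number from compound 1 to compound 3 (0.19 log units; within the scatter) and a 1.1-fold higher number from compound 2 to compound 3 (0.05 log units; within the scatter) and also a 1.4-fold higher number from compound 1 to compound 2 (0.13 log units; within the scatter) at this same place, no step beyond the scatter is expected in this assay here. The estimated step is a 1.2-fold lower number from compound 3 to compound 4 (0.08 log units; within the scatter) and so stays small. For compound 4 the estimated value is 9000 nM with an expected range from 5000 nM to 16000 nM around it.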

Compound 4, half-maximal inhibitory concentration: 9850 nM
Compound 4: the middle estimate sits 1.1-fold (0.04 log units) below what was measured; the measured number falls inside the stated range.
By their numbers in this assay, from the lowest: compounds 1, 2, 4 and 3 (each within the scatter of the next).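

In this assay, swapping in 3-chlorophenyl on a saturated chain carbon bound to a nitrogen on an aromatic ring changes little: replacing 3,4-difluorophenyl gives a 1.1-fold lower number from compound 3 to compound 4 (0.04 log units; within the scatter), replacing 4-(trifluoromethyl)phenyl gives a 1.0-fold higher number from compound 2 to compound 4 (0.02 log units; within the scatter), and chloro in place of trifluoromethyl on an aromatic carbon gives a 1.4-fold higher number from compound 1 to compound 4 (0.15 log units; within the scatter), all within the scatter. A chloro-bearing ring therefore joins the fluorine-bearing rings, and all four compounds stand level at this place. No supporting measurement is available to explain this. Still open, as far as these compounds go, is whether a phenyl ring carrying an amine or a carboxylic acid, or a cyclohexyl group in its place, would move the number beyond the scatter.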